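The compounds below may be only part of what the source reports. "The series", "measured", "known", "first", "only" and "open" are said of these compounds alone.

Three compounds share a core in which a five-membered aromatic ring bearing two nitrogens is linked to a sulfur-containing heterocycle, and all three have been tested in a functional assay on BJAB cells (Homo sapiens) for antiproliferative activity, with a stated time of 4 days; a higher number here means that more compound is needed for the effect, a lower number that less compound is needed. Compound 1, `Cc1ccc(-c2c(C)nn(-c3nc(-c4ccc(Cl)c(Cl)c4)c(SC(C)C)s3)c2C(=O)O)cc1`, gives 3800 nM in this assay, the lowest of the three numbers. Compound 2, `Cc1c(-c2cc(Cl)cc(Cl)c2)c(C(=O)O)nn1-c1nc(-c2cc(Cl)ccc2F)c(SC(C)C)s1`, gives 4800 nM, which lies within the usual scatter of compound 1, so the two cannot be told apart. Compound 3, `CCSc1sc(-n2nc(C)c(Cc3ccccc3[N+](=O)[O-])c2C(=O)OC)nc1-c1ccc(Cl)c(Cl)c1`, gives 106000 nM, a number far beyond the scatter from compound 1 and clearly the weaker of that pair.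

The next compound, compound 4, `Cc1cccc(-c2c(C)nn(-c3nc(-c4ccc(Cl)c(Cl)c4)c(SC(C)C)s3)c2C(=O)O)c1`, has the same atoms as compound 1 joined differently: 3-methylphenyl in place of 4-methylphenyl on an aromatic carbon. Within the data shown here, the only change is where the methyl group sits on the phenyl ring, which itself stays on the aromatic carbon of the five-membered ring.

Among the measured compounds shown here, no measured pair here shows what such a shift of a methyl group does, so the expectation rests on the change being small. The step from compound 1 to compound 4 is expected to be a 1.2-fold higher number from compound 1 to compound 4 (0.07 log units; within the scatter), that is, no movement beyond the scatter. For compound 4 the estimated value in this assay is therefore 4500 nM, with a range from 1500 nM to 13000 nM.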

Compound 4, half-maximal effective concentration: 17000 nM
For compound 4 the middle estimate is 3.8-fold (0.58 log units) below the measured one; the measured number lies above the stated range.
By their numbers in this assay, from the lowest: compounds 1 and 2 (each within the scatter of the next); then compound 4; then compound 3.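

Moving the methyl group on the phenyl ring, with nothing else changed, gives in this assay a 4.5-fold higher number from compound 1 to compound 4 (0.65 log units; beyond the scatter). Among these compounds, this shows that the place of one methyl group on this ring can shift the number by more than the scatter, even though 4-methylphenyl and 3-methylphenyl have the same atoms and the same counts of donors and acceptors, and it is a comparison the earlier compounds could not give, as no two of them differ in only one place. Nothing measured here accounts for the step.

As far as these compounds go, this is a single pair, so it stays open whether a chlorine or a methoxy group would show a step of similar size when shifted in the same way, and whether a plain phenyl without any methyl group would give a number closer to compound 1 or to compound 4. From the compounds shown here alone, it is also open whether the step would hold if an amide took the place of the carboxy group on the neighbouring ring atom.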